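Swapping an Amide Side Chain for an Aryl Ester

This account rests on a few compounds, and the source may have more. Where it says the series, first, only, none or still open, it means among the compounds named here.

Compound 1 `CCN(CC)CCNC(=O)c1ccc(C(CC)(CC)c2ccc(OCC(O)C(C)(C)C)c(C)c2)n1CC` is the starting point. For the measured compounds named here, in an assay on HL-60 cells for agonist activity at vitamin D3 receptor (Homo sapiens), read by microscopy, with a stated time of 96 h (a higher number here means that more compound is needed for the effect, a lower number that less compound is needed), compound 1 gives 110 nM, the only plain number among the three measured compounds. Compound 2 `CCn1c(C(=O)Nc2ccc(OC(F)(F)F)cc2)ccc1C(CC)(CC)c1ccc(OCC(=O)C(C)(C)C)c(C)c1` reaches only a limit, > 50000 nM. Compound 3 `CCn1c(C(=O)Nc2cccc(C(F)(F)F)c2)ccc1C(CC)(CC)c1ccc(OCC(=O)C(C)(C)C)c(C)c1` likewise gives a limit, > 50000 nM. The step that the two limits leave unreadable from compound 2 to compound 3 therefore cannot be sized. Compound 4 `CCn1c(C(=O)Oc2ccc(CCO)cc2)ccc1C(CC)(CC)c1ccc(OCC(O)C(C)(C)C)c(C)c1` differs from compound 1 by a group of 10 heavy atoms (8 carbon, 2 oxygen; one six-membered aromatic ring of carbon only) in place of a group of 8 heavy atoms (6 carbon, 2 nitrogen; no ring), on a carbonyl carbon. Going by the values given here, no measured step covers this change; compounds 2 and 3 also carry aromatic groups on the carbonyl, yet they differ from compound 1 in other places too, so the limits the limit of > 50000 nM in this assay, at which 2 of the 3 values shown sit, give only a weak hint toward lower potency. Compound 4 is expected to need more compound, estimated at 1500 nM with a range of 150 nM to 30000 nM, a step of a 14-fold higher number from compound 1 to compound 4 (1.13 log units; beyond the scatter).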

Compound 4, half-maximal effective concentration: 5100 nM
Compound 4: middle estimate off by 3.4-fold (0.53 log units), on the low side, and the stated range covers the measured number.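

Putting the group with the six-membered aromatic ring on the carbonyl carbon, in place of (2-(diethylamino)ethyl)amino, gives in this assay a 46-fold higher number from compound 1 to compound 4 (1.67 log units; beyond the scatter), the first readable size for a change at this place, since the earlier step cannot be read. Compound 4 still gives a plain number rather than a limit, so this replacement costs potency without removing the effect. Nothing shown explains the size of this step.

Still open, from the compounds shown here alone, is whether the loss follows from the missing diethylamino group or from the ester link replacing the amide. A carboxylic acid on this carbonyl, or an amide carrying the same 2-hydroxyethylphenyl group, could help separate the two.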